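The source may report more compounds than this note shows. Statements on the series, on what has been measured and on what is new or still open speak of the compounds shown alone.

Among the measured compounds shown here, in a functional assay on HeLa cells (Homo sapiens) for antiproliferative activity, read by fluorescence and resazurin assay, with a stated time of 48 h (a lower number here means that less compound is needed, a higher number that more compound is needed for the effect), compound 1 `COc1cc(-c2nccc3c(OC)c(OC)c(OC)cc23)ccc1O` gives 50000 nM, the highest of the three numbers measured so far. Compound 2 `COc1cc2c(-c3cc(OC)c(OC)c(OC)c3)nccc2cc1OP(=O)(O)O` gives 170 nM and compound 3 `COc1ccc2ccnc(-c3cc(OC)c(OC)c(OC)c3)c2c1` gives 180 nM, both far lower than compound 1. Compound 4 `COc1cc(-c2nccc3c(OC)c(OC)c(OC)cc23)ccc1OP(=O)(O)O` departs from compound 1 by a single change: a group of 4 heavy atoms (3 oxygen, 1 phosphorus; no ring) in place of a hydrogen atom, on an oxygen on an aromatic ring. For the measured compounds named here, only one measured step bears on this, and only loosely, as it lies on a different core and on an aromatic carbon: a 1.1-fold higher number from compound 2 to compound 3 (0.02 log units; within the scatter). That step stays within the scatter, so no step beyond the scatter is expected in this assay. Compound 4 is estimated at 40000 nM, with an expected range from 8000 nM to 100000 nM. The expected step is a 1.3-fold lower number from compound 1 to compound 4 (0.10 log units; within the scatter).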

Compound 4, half-maximal effective concentration: > 100000 nM
Compound 4: no number, only a limit; the forecaster's own chance of this, stated with the estimate: 30%; middle value at least 2.5-fold (0.39 log units) away from the limit.
By their numbers in this assay, from the lowest: compounds 2 and 3 (each within the scatter of the next); then compound 1. At a limit, above all of these: compound 4.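

In this assay compound 4 gives only a limit, > 100000 nM, not a number. On this oxygen on an aromatic ring, the group of 4 heavy atoms (3 oxygen, 1 phosphorus) gives an at least 2.0-fold higher number from compound 1 to compound 4 (0.30 log units; that floor lies within the scatter), so the change does not bring the high number of compound 1 down, something the step on the other core could not show. Since that floor lies within the scatter, neither the size of the rise nor whether there is one can be read: the limit of > 100000 nM in this assay, at which 1 of the 4 values shown sits.

The compounds shown leave open whether a methyl or an acetyl group on this same oxygen would lower the number. They also leave open how a plain hydroxyl in place of the same group would behave on the core of compound 2.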